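Dihydroindole to indole: a microsomal clearance question

The source may report more compounds than this note shows. Statements on the series, on what has been measured and on what is new or still open speak of the compounds shown alone.

Of the compounds shown here, three on a shared core have been measured in an ADME assay on microsomes from liver (Rattus norvegicus) for metabolic stability, read by LC-MS; on this read-out higher numbers stand for fast clearance and lower numbers for slow clearance. Compound 1 `COc1cc(N2CCN(C(=O)Cn3ncc4ccccc43)CC2)ccc1-c1cnc(C)o1` gives 77 mL.min-1.g-1, compound 2 `COc1cc(C2CCN(C(=O)N[C@@H](C)c3cccc4ccccc34)CC2)ccc1-c1cnc(C)o1` gives 170 mL.min-1.g-1, and compound 3 `COc1cc(N2CCN(C(=O)CN3CCc4ccccc43)CC2)ccc1-c1cnc(C)o1` gives 160 mL.min-1.g-1. Compound 3 stands second highest of the three, close to compound 2, while compound 1 sits clearly lower. For the measured compounds named here, the single one-place step among them, a 2.1-fold higher number from compound 1 to compound 3 (0.32 log units; beyond the scatter), is the only guide. Compound 4 `COc1cc(N2CCN(C(=O)Cn3ccc4ccccc43)CC2)ccc1-c1cnc(C)o1` differs from compound 3 thus: 1H-indol-1-yl in place of 2,3-dihydro-1H-indol-1-yl on a saturated chain carbon bound to a carbonyl carbon. Compound 1 also carries an aromatic five-membered ring with one hetero atom at that position and gives 77 mL.min-1.g-1, but indole is not indazole, so only a partial return is expected. Compound 4 is therefore estimated at 110 mL.min-1.g-1, within 60 mL.min-1.g-1 to 220 mL.min-1.g-1, an expected step of a 1.5-fold lower number from compound 3 to compound 4 (0.16 log units; within the scatter).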

Compound 4, intrinsic clearance in microsomes: 140 mL.min-1.g-1
Compound 4: the middle estimate sits 1.3-fold (0.10 log units) below what was measured; the range from low to high includes it.
By their numbers in this assay, from the lowest: compounds 1, 4, 3 and 2 (each within the scatter of the next, the first and the last beyond it).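

In this assay, the step to the fully aromatic ring is a 1.1-fold lower number from compound 3 to compound 4 (0.06 log units; within the scatter), so this change at the saturated chain carbon bound to a carbonyl carbon does not separate the two compounds. The other comparison at this position is a 1.8-fold higher number from compound 1 to compound 4 (0.26 log units; within the scatter), so compound 4 lies within the scatter of two compounds that lie beyond it of each other. Nothing available explains these readings. From the compounds shown here alone, whether a longer chain in place of that chain carbon, or a carboxylic acid on 1H-indol-1-yl, would give a step beyond the scatter remains open.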